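Shrinking the Charged Ring: From Compound 2 to Compound 3

The source may hold more compounds than are shown below. What is called first, only, known or untested is meant among the compounds shown, and "the series" means these compounds.

Compound 1 `CN(C)c1ccc2c(=O)c(C(=O)Nc3cc(F)cc(F)c3)cn(-c3ccc(Cl)c(OCCCCCCC[N+]4(C)CCCC4)c3)c2n1`: 76.1%
Compound 2 `CC[N+]1(CCCCCCCOc2cc(-n3cc(C(=O)Nc4cc(F)cc(F)c4)c(=O)c4ccc(N(C)C)nc43)ccc2Cl)CCCCC1`: "not active" (no number reported)

In an assay on LX2 cells for inhibition of COL1A1 promoter (Homo sapiens), read by a luciferase reporter, with a stated time of 24 h, tested at 50 uM (on this read-out higher numbers stand for a stronger effect at the one concentration tested and lower numbers for a weaker effect), compound 1 gives 76.1%. Compound 2 is reported in this assay as "not active" (no number reported), so it stands with no single number and cannot be placed on the scale. Compound 3 `CC[N+]1(CCCCCCCOc2cc(-n3cc(C(=O)Nc4cc(F)cc(F)c4)c(=O)c4ccc(N(C)C)nc43)ccc2Cl)CCCC1` differs from compound 2 by a group of 7 heavy atoms (6 carbon, 1 nitrogen; one five-membered non-aromatic ring with 1 hetero atom) in place of a group of 8 heavy atoms (7 carbon, 1 nitrogen; one six-membered non-aromatic ring with 1 hetero atom), on a saturated chain carbon, seven bonds along the chain from an oxygen on an aromatic ring. For the measured compounds named here, no measured step of this kind exists, so the size of the shift in this assay is unknown; compound 1, which also carries one five-membered non-aromatic ring, gives 76.1%, which suggests a gain rather than a loss. Compound 3 is expected to give about 45% in this assay, within 10% to 80%.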

Compound 3, a percentage reported as inhibition, at one concentration (the size of the read-out at that concentration, not a potency): 96.4%
Beside the measured number, compound 3's estimate is 51.4 percentage points below it, outside the stated range (above it).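

In this assay the ring size on this chain matters: with the five-membered ring compound 3 gives 96.4% while compound 2, with the six-membered ring, is reported as not active, though without a number for compound 2 this change has no measurable size. With the five-membered ring kept, methyl in place of hydrogen on the saturated chain carbon bound to the ring nitrogen gives a number 20.3 percentage points higher from compound 1 to compound 3 (beyond the scatter) and so raises the effect further. No measurement shown explains either result.

Going by these compounds, whether a propyl group on that nitrogen would raise the effect further remains open, as does the outcome with a morpholine ring.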